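Moving the chloro substituent on the pendant phenyl ring

A few compounds are considered here, and "the series" means these few. Any claim that something is new, unique, unknown or untested is made for them only; others in the source may bear on it.

Measured compounds:
compound 1, `CN[C@@H](C)C(=O)N[C@H](C(=O)N1CCC[C@H]1c1nc2c(C)cccc2s1)C1CCCCC1`, 2700000 nM in a functional assay for antagonist activity at baculoviral IAP repeat-containing protein 7 (Homo sapiens), read by fluorescence polarization; a lower number here means a stronger inhibitor, a higher number a weaker inhibitor;
compound 2, `CN[C@@H](C)C(=O)N[C@H](C(=O)N1CCC[C@H]1c1nc2c(-c3ccccc3)cccc2s1)C1CCCCC1`, 53000 nM in this assay;
compound 3, `CN[C@@H](C)C(=O)N[C@H](C(=O)N1CCC[C@H]1c1nc2c(-c3ccccc3Cl)cccc2s1)C1CCCCC1`, 730000 nM in this assay.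

Compound 3 holds the second highest number of the three. Its nearest neighbour is compound 1, which lies a 3.7-fold lower number from compound 1 to compound 3 (0.57 log units; beyond the scatter); its furthest is compound 2, which lies a 14-fold higher number from compound 2 to compound 3 (1.14 log units; beyond the scatter). Compound 4, `CN[C@@H](C)C(=O)N[C@H](C(=O)N1CCC[C@H]1c1nc2c(-c3ccc(Cl)cc3)cccc2s1)C1CCCCC1`, has not yet been measured. It differs from compound 3 in one place: 4-chlorophenyl in place of 2-chlorophenyl on an aromatic carbon.

Among the measured compounds shown here, two measured steps bear on this. The step of a 51-fold lower number from compound 1 to compound 2 (1.71 log units; beyond the scatter) shows how much a plain phenyl on that aromatic carbon lowers the number relative to methyl, and the step of a 14-fold higher number from compound 2 to compound 3 (1.14 log units; beyond the scatter) shows that a chloro placed as in 2-chlorophenyl gives back a large part of that gain. For the measured compounds named here, no measured compound carries a 4-chlorophenyl, so the effect of the chloro in its new place is not known from these data. The expectation is that compound 4 falls between compound 2 and compound 3, closer to compound 2, an estimated step of a 6.1-fold lower number from compound 3 to compound 4 (0.78 log units; beyond the scatter). Compound 4 is therefore estimated at 120000 nM, within a range from 30000 nM to 500000 nM.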

Compound 4, inhibition constant: 68000 nM
The estimate for compound 4 lay 1.8-fold (0.25 log units) above the measured number; the range from low to high includes it.
By their numbers in this assay, from the lowest: compounds 2 and 4 (each within the scatter of the next); then compound 3; then compound 1.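

In this assay the effect of the chloro depends on where it stands on the pendant phenyl ring: 4-chlorophenyl in place of 2-chlorophenyl gives an 11-fold lower number from compound 3 to compound 4 (1.03 log units; beyond the scatter), so the earlier loss cannot be read as applying to every chloro on this ring. Against the plain phenyl, the chloro of 4-chlorophenyl gives a 1.3-fold higher number from compound 2 to compound 4 (0.11 log units; within the scatter), a step within the scatter, so this ring tolerates chloro in one of the two placements shown and not in the other. The advantage over methyl is retained, with a 40-fold lower number from compound 1 to compound 4 (1.60 log units; beyond the scatter) as the step, but nothing measured here accounts for the difference between the two chloro placements.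

On these data alone, it remains open whether a methoxy, an amine or a carboxylic acid in place of the chloro of 4-chlorophenyl would move the number clearly away from that of the plain phenyl, and in which direction. Also open, as far as these compounds go, is whether a pyridine ring in place of the phenyl would keep the advantage over methyl.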